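This account rests on a few compounds, and the source may have more. Where it says the series, first, only, none or still open, it means among the compounds named here.

In a functional assay on P388 cells (Mus musculus) for cytotoxicity (on this read-out higher numbers stand for weaker inhibition and lower numbers for stronger inhibition), compound 3 `COc1ccccc1Cc1cn(C2CC2)c2c(F)c(-c3cc(C)nc(C)c3)c(F)cc2c1=O` gives the highest number of the three measured compounds, 37000 nM. Compound 1 `Cc1cc(-c2c(F)cc3c(=O)c(Cc4ccccc4O)cn(C4CC4)c3c2F)cc(C)n1` gives 670 nM and compound 2 `Cc1cc(-c2c(F)cc3c(=O)c(Cc4ccc[nH]4)cn(C4CC4)c3c2F)cc(C)n1` gives 930 nM, with a 1.4-fold higher number from compound 1 to compound 2 (0.14 log units; within the scatter). Compound 4 `Cc1cc(-c2c(F)cc3c(=O)c(Cc4cccc(O)c4O)cn(C4CC4)c3c2F)cc(C)n1` carries 2,3-dihydroxyphenyl in place of 2-methoxyphenyl on a saturated chain carbon bound to an aromatic carbon. The closest guide is a 55-fold higher number from compound 1 to compound 3 (1.74 log units; beyond the scatter), which came with methyl in place of hydrogen on an oxygen on an aromatic ring, and a 40-fold higher number from compound 2 to compound 3 (1.60 log units; beyond the scatter) is of similar size. For the measured compounds named here, compound 4 has no such methyl, but no measured compound carries 2,3-dihydroxyphenyl, so the size remains uncertain. The expected result is a 62-fold lower number from compound 3 to compound 4 (1.79 log units; beyond the scatter), a large drop. For compound 4, the estimated value is 600 nM, with an expected range of 150 nM to 3000 nM.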

Compound 4, half-maximal inhibitory concentration: 880 nM
Beside the measured number, compound 4's estimate is 1.5-fold (0.17 log units) below it; the range from low to high includes it.
By their numbers in this assay, from the lowest: compounds 1, 4 and 2 (each within the scatter of the next); then compound 3.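

In this assay, 2,3-dihydroxyphenyl at this position gives a number far from that of the methylated compound 3, a 42-fold lower number from compound 3 to compound 4 (1.62 log units; beyond the scatter), so a ring with free hydroxy groups and no methyl also sits with the low numbers. A further hydroxy on the ring adds nothing beyond the scatter, a 1.3-fold higher number from compound 1 to compound 4 (0.12 log units; within the scatter), and the hydroxy-free pyrrole of compound 2 matches too, a 1.1-fold lower number from compound 2 to compound 4 (0.02 log units; within the scatter). No measured evidence here explains these results. Going by these compounds, whether an amine or a carboxylic acid on this ring would also keep the number low remains open.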